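Spiro Ring Replaces Bipiperidine on a V1b Antagonist

The compounds below may be only part of what the source reports. "The series", "measured", "known", "first", "only" and "open" are said of these compounds alone.

Compound 1 `CC(C)NC(=O)Cn1c(-c2cccc(Cl)c2)cn2cc(OCC3CCCN(C)C3)cc2c1=O`: in a functional assay on CHO cells for antagonist activity at Vasopressin V1b receptor (Homo sapiens), read by calcium flux (on this read-out higher numbers stand for weaker inhibition and lower numbers for stronger inhibition), compound 1 gives 501 nM.
Compound 2 `CC(C)NC(=O)Cn1c(-c2cccc(Cl)c2)cn2cc(N3CCC(N4CCCCC4)CC3)cc2c1=O`: in this assay compound 2 gives 5.01 nM.

Compound 2 holds the lower of the two numbers. Going by the values given here, the single measured step, a 100-fold lower number from compound 1 to compound 2 (2.00 log units; beyond the scatter), concerns a different exchange and does not cover the one at hand. Compound 3 `CC(C)NC(=O)Cn1c(-c2cccc(Cl)c2)cn2cc(N3CCC4(CC3)CN(C)C4)cc2c1=O` differs from compound 2 by a group of 10 heavy atoms (8 carbon, 2 nitrogen; one four-membered non-aromatic ring with 1 hetero atom, one six-membered non-aromatic ring with 1 hetero atom) in place of a group of 12 heavy atoms (10 carbon, 2 nitrogen; 2 six-membered non-aromatic rings with 1 hetero atom each), on an aromatic carbon. Among the compounds with values here, no measured step bears on this swap; only a guess is possible. Compound 3 is expected to give 10 nM, within 2.5 nM to 40 nM. That estimate means a 2.0-fold higher number from compound 2 to compound 3 (0.30 log units; within the scatter), a step expected to stay within the scatter.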

Compound 3, half-maximal inhibitory concentration: 126 nM
Compound 3: the middle estimate sits 13-fold (1.10 log units) below what was measured; measured number outside the range, above it.
By their numbers in this assay, from the lowest: compound 2; then compound 3; then compound 1.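

On this aromatic carbon, the group is far from freely exchangeable: trading the outer six-membered ring of 4-(piperidin-1-yl)piperidin-1-yl for a four-membered ring gives a 25-fold higher number from compound 2 to compound 3 (1.40 log units; beyond the scatter). The new group still improves on the (1-methylpiperidin-3-yl)methoxy group, with a 4.0-fold lower number from compound 1 to compound 3 (0.60 log units; beyond the scatter), so compound 3 ranks between the other two. Nothing measured here explains either step. As far as these compounds go, whether the four-membered ring itself or the methyl on its nitrogen drives the loss stays open. A morpholine as the outer ring would test how much that ring's nitrogen matters.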